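Ether chain extension in the dimethylaminoethylamino series

The source may report more compounds than this note shows. Statements on the series, on what has been measured and on what is new or still open speak of the compounds shown alone.

Compound 3 `CCOc1ccc2c(NCCN(C)C)ccnc2c1` gives 4620 nM in a functional assay on SK-OV-3 cells (Homo sapiens) for cytotoxicity, read by MTT assay, with a stated time of 48 h (a lower number here means a stronger inhibitor, a higher number a weaker inhibitor), the highest of the two numbers available; the nearest is compound 1 `CN(C)CCNc1ccnc2cc(OCc3ccc(F)cc3)ccc12`, which gives 890 nM in this assay. Compound 2 `CCCCCCOc1ccc2c(Cl)ccnc2c1` reaches only the limit of > 10000 nM in this assay. Compound 4 `CCCCCCOc1ccc2c(NCCN(C)C)ccnc2c1` differs from compound 3 by butyl in place of hydrogen on a saturated chain carbon, two bonds along the chain from an oxygen on an aromatic ring. Among the measured compounds shown here, the single measured step at the ether position is a 5.2-fold higher number from compound 1 to compound 3 (0.72 log units; beyond the scatter), showing that the group on that oxygen does shift this assay. For the measured compounds named here, compound 2 also carries a hexyloxy chain, but its value is a limit of > 10000 nM in this assay, at which 1 of the 3 values shown sits, and it differs at a second position, so it gives no step. A modest step toward a lower number is therefore expected, a 1.8-fold lower number from compound 3 to compound 4 (0.27 log units; within the scatter). Compound 4 is estimated at 2500 nM, between 700 nM and 9000 nM.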

Compound 4, half-maximal inhibitory concentration: 1860 nM
Estimate against measurement, compound 4: 1.3-fold (0.13 log units) above; measured number inside the range.
By their numbers in this assay, from the lowest: compound 1; then compound 4; then compound 3. At a limit, above all of these: compound 2.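

Ethoxy to hexyloxy moves this assay on its own, with a 2.5-fold lower number from compound 3 to compound 4 (0.40 log units; beyond the scatter), so a plain alkyl chain on this oxygen shifts the number without any aromatic ring in the group. The hexyloxy chain does not match the aryl-bearing group, since pentyl in place of 4-fluorophenyl gives a 2.1-fold higher number from compound 1 to compound 4 (0.32 log units; beyond the scatter). With hexyloxy held fixed, (2-(dimethylamino)ethyl)amino in place of chloro gives an at least 5.3-fold lower number from compound 2 to compound 4 (0.73 log units; beyond the scatter), a step read from a limit and not from a number.

Going by these compounds, whether a longer chain lowers the number further remains open, as does the effect of an amine or a carboxylic acid at the chain end.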